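A few compounds are considered here, and "the series" means these few. Any claim that something is new, unique, unknown or untested is made for them only; others in the source may bear on it.

Compound 1 `CC1CCN(c2nc(C(F)(F)F)ccc2CNC(=O)Nc2ccc3ccccc3n2)CC1` is the starting point of this step. In an assay on isolated protein for antagonist activity at transient receptor potential cation channel subfamily V member 1 (Homo sapiens), read by FLIPR (on this read-out lower numbers stand for stronger inhibition and higher numbers for weaker inhibition), compound 1 gives "not active" (no number reported), so no number places it among the other compounds; it stands apart from compound 2 `CC1CCN(c2nc(C(F)(F)F)ccc2CNC(=O)Nc2cccc3cnccc23)CC1` and compound 3 `CC1CCN(c2nc(C(F)(F)F)ccc2CNC(=O)Nc2cccc3ncccc23)CC1`, which both carry an attached bicyclic group of a different kind. In this assay, for the measured compounds named here, compound 2 gives 0.2 nM and compound 3 gives 0.7 nM, and the only measured step between neighbours, a 3.5-fold higher number from compound 2 to compound 3 (0.54 log units; beyond the scatter), concerns the exchange of those two groups, which is not the exchange made here.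

Compound 4 `CC1CCN(c2nc(C(F)(F)F)ccc2CNC(=O)Nc2nccc3cccnc23)CC1` differs from compound 1 in one place: a group of 10 heavy atoms (8 carbon, 2 nitrogen; 2 six-membered aromatic rings with 1 hetero atom each) in place of a group of 10 heavy atoms (9 carbon, 1 nitrogen; one six-membered aromatic ring of carbon only, one six-membered aromatic ring with 1 hetero atom), on an amide-type nitrogen. Going by the values given here, the entering group, with 2 six-membered aromatic rings with 1 hetero atom each, resembles the leaving quinolin-2-yl more closely than it resembles the groups of compound 2 or compound 3, and no measured step shows what one more ring nitrogen in this part of the molecule does. The step from compound 1 to compound 4 therefore cannot be sized from the data; the expectation rests only on the inactivity of compound 1. Compound 4 is expected to be weak in this assay, with an estimated value of 3000 nM (range 100 nM to 30000 nM), and a fair chance that only a limit is reported.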

Compound 4, inhibition constant: "not active" (no number reported)
No number was reported for compound 4; no gap can be computed for the estimate.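

In this assay, for the compounds shown here, compound 1 gives "not active" (no number reported) and compound 4 gives "not active" (no number reported), so no step between the two can be read. Nothing shown accounts for this result. The compounds shown leave open whether the exchange at the amide-type nitrogen changes activity at all, since neither compound has a number.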